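A few compounds are considered here, and "the series" means these few. Any claim that something is new, unique, unknown or untested is made for them only; others in the source may bear on it.

Of the compounds shown here, three built on one shared core have been tested in a functional assay on HCT-116 cells (Homo sapiens) for antiproliferative activity, read by MTT assay, with a stated time of 48 h; on this read-out higher numbers stand for weaker inhibition and lower numbers for stronger inhibition. Compound 1 `O=C(Nc1cccc(/C=C/C(=O)c2nc3ccccc3[nH]2)c1)c1ccccc1` gives 2440 nM in this assay. Compound 2 `O=C(Nc1cccc(/C=C/C(=O)c2nc3ccccc3[nH]2)c1)c1ccc(Cl)cc1` carries a chloro group on an aromatic carbon, and in this assay compound 2 gives 2270 nM. Compound 3 `O=C(Nc1cccc(/C=C/C(=O)c2nc3ccccc3[nH]2)c1)c1cccc(Br)c1` carries a bromo group instead, and in this assay compound 3 gives 1560 nM, the lowest of the three numbers, although the steps of a 1.6-fold lower number from compound 1 to compound 3 (0.19 log units; within the scatter) and a 1.5-fold lower number from compound 2 to compound 3 (0.16 log units; within the scatter) both stay within the scatter, as does a 1.1-fold lower number from compound 1 to compound 2 (0.03 log units; within the scatter). Compound 4 `Cc1cccc(C(=O)Nc2cccc(/C=C/C(=O)c3nc4ccccc4[nH]3)c2)c1` differs from compound 3 by methyl in place of bromo on an aromatic carbon. Within the data shown here, no measured pair exchanges bromo for methyl, so only indirect evidence remains: each change made so far on this ring, adding chloro or adding bromo, shifted the number by less than the scatter. The step from compound 3 to compound 4 is therefore expected to be small, a 1.2-fold higher number from compound 3 to compound 4 (0.09 log units; within the scatter), with no firm direction. Compound 4 is expected to give about 1900 nM, within a range from 900 nM to 4000 nM.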

Compound 4, half-maximal inhibitory concentration: 1420 nM
Compound 4: the middle estimate sits 1.3-fold (0.13 log units) above what was measured; measured number inside the range.
By their numbers in this assay, from the lowest: compounds 4, 3, 2 and 1 (each within the scatter of the next).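

In this assay, replacing bromo with methyl on this aromatic carbon, meta to a large group, gives a step within the scatter (a 1.1-fold lower number from compound 3 to compound 4 (0.04 log units; within the scatter)), so this assay does not tell these two single-atom groups apart. Methyl is the first group here that is not a halogen, yet its steps from the other two compounds also stay within the scatter (a 1.6-fold lower number from compound 2 to compound 4 (0.20 log units; within the scatter)) and (a 1.7-fold lower number from compound 1 to compound 4 (0.24 log units; within the scatter)). Across all four compounds, then, no change on this ring has produced a step beyond the scatter, and no measurement bears on why that is so. Still open, as far as these compounds go, is whether a different kind of group on this ring, such as an amine, a carboxylic acid or a longer chain, would give a step beyond the scatter.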